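Removing the Nitro Group: Expected Cytotoxicity of Compound 4

The source may hold more compounds than are shown below. What is called first, only, known or untested is meant among the compounds shown, and "the series" means these compounds.

Compound 2 `C#CCN(c1nc(-c2cccc([N+](=O)[O-])c2)no1)C1CCCCC1` gives 34.2 ug/mL in an ADME assay on RAW264.7 cells (Mus musculus) for cytotoxicity, read by MTT assay, with a stated time of 48 h; on this read-out lower numbers stand for higher toxicity in this test and higher numbers for lower toxicity in this test. Of the three measured compounds, compound 1 `C#CCN(c1nc(-c2cccc(Br)c2)no1)C1CCCCC1` gives 31.8 ug/mL, a number within the scatter of compound 2, while compound 3 `CC(=O)OC[C@H]1O[C@H](OC[C@H](Cn2cc(COc3ccc(-c4noc(C)n4)cc3)nn2)OC(C)=O)C=C[C@@H]1OC(C)=O` gives 112 ug/mL, a number that lies beyond the scatter above compound 2. The change to compound 4 `C#CCN(c1nc(-c2ccccc2)no1)C1CCCCC1` is hydrogen in place of nitro on an aromatic carbon. For the measured compounds named here, one measured step bears on this site: the swap of bromo for nitro on the same aromatic carbon, a 1.1-fold higher number from compound 1 to compound 2 (0.03 log units; within the scatter). Two different groups at this position gave numbers within the scatter of each other, so removing the group altogether is expected to shift the number little. For compound 4 the estimated step is a 1.0-fold lower number from compound 2 to compound 4 (0.02 log units; within the scatter). Compound 4 is expected to show 33 ug/mL, with a range from 20 ug/mL to 55 ug/mL.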

Compound 4, half-maximal cytotoxic concentration: 32.1 ug/mL
The estimate for compound 4 lay 1.0-fold (0.01 log units) above the measured number; low and high end bracket the measured number.
By their numbers in this assay, from the lowest: compounds 1, 4 and 2 (each within the scatter of the next); then compound 3.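

Removing the group altogether does not move the number beyond the scatter in this assay: the change gives a 1.1-fold lower number from compound 2 to compound 4 (0.03 log units; within the scatter), and replacing bromo gives a 1.0-fold higher number from compound 1 to compound 4 (0.00 log units; within the scatter). Nitro, bromo and plain hydrogen on this aromatic carbon therefore cannot be told apart in this test, so neither larger group is needed to keep the number in this range. Nothing available explains this lack of difference. From the compounds shown here alone, whether an amine or a carboxylic acid on this carbon would leave the number within the scatter remains open. So does the effect of the same changes on other carbons of this ring.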